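A few compounds are considered here, and "the series" means these few. Any claim that something is new, unique, unknown or untested is made for them only; others in the source may bear on it.

Compound 1 `Cc1cc(C(=O)O)ccc1CN1CCC[C@H](O[C@H](CO)c2ccccc2)[C@@H]1c1ccccc1` gives > 200000 nM in an assay on isolated protein for activation of cGMP-dependent protein kinase 1 (Homo sapiens), read by ADP-Glo, with stated times of 30 min and 2 h; a lower number here means that less compound is needed, a higher number that more compound is needed for the effect. Compound 2 `OC[C@@H](O[C@H]1CCCN(Cc2ncc[nH]2)[C@H]1c1ccccc1)c1cc(Cl)cc(Cl)c1` gives > 200000 nM in this assay. Compound 3 `Cc1cc(C(=O)O)ccc1CN1CCC[C@H](O[C@@H](CC(C)(C)O)c2cc(Cl)cc(Cl)c2)[C@@H]1c1ccccc1` gives 8800 nM in this assay.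

The value of compound 2 is a limit of this assay, not a number; compound 2 stands at the limit of > 200000 nM in this assay, at which 2 of the 3 values shown sit. The value of compound 1 is likewise only a limit. Compound 3 alone gives a number, and it combines a dichlorophenyl with an acid-bearing benzyl on the ring nitrogen.

Compound 4 `Nc1cc(C(=O)O)ccc1CN1CCC[C@H](O[C@H](CO)c2cc(Cl)cc(Cl)c2)[C@@H]1c1ccccc1` arises from compound 2 by 2-amino-4-carboxyphenyl in place of 1H-imidazol-2-yl on a saturated chain carbon bound to an amine nitrogen in a ring. Since compound 3 gives 8800 nM with a related acid-bearing group, a gain in potency is expected: the expected step is an at least 16-fold lower number from compound 2 to compound 4 (1.22 log units; beyond the scatter). Compound 4 is estimated at 12000 nM, with a range from 2000 nM to 90000 nM.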

Compound 4, half-maximal effective concentration in the cGMP-dependent protein kinase 1 assay: 168000 nM
The estimate for compound 4 lay 14-fold (1.15 log units) below the measured number; measured number outside the range, above it.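

In the cGMP-dependent protein kinase 1 assay the change gives an at least 1.1-fold lower number from compound 2 to compound 4 (0.07 log units; that floor lies within the scatter), so compound 4 yields a number, but a real gain from this acid-bearing group at this place can be neither shown nor ruled out. In the cGMP-dependent protein kinase 1 assay compound 2 gives > 200000 nM, and the step is only a floor because this value is a limit: the limit of > 200000 nM in the cGMP-dependent protein kinase 1 assay, at which 2 of the 4 values shown sit. In a physicochemical assay for solubility, at pH 7 (on this read-out higher numbers stand for higher solubility and lower numbers for lower solubility), compound 2 gives 120000 nM and compound 4 gives 78000 nM; the same change gives a 1.5-fold lower number from compound 2 to compound 4 (0.19 log units; within the scatter), so this read-out does not separate the two compounds. As far as these compounds go, whether a tetrazole or a sulfonamide in place of the carboxylic acid would give a lower number in the cGMP-dependent protein kinase 1 assay stays open.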